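The source may report more compounds than this note shows. Statements on the series, on what has been measured and on what is new or still open speak of the compounds shown alone.

Compound 1 `COc1ccc(C(=O)/C=C/c2ccc(OCc3cn(Cc4ccccc4F)nn3)cc2)cc1`: 19%
Compound 2 `COc1ccc(C(=O)/C=C/c2ccc(OCc3cn(Cc4ccc(F)cc4)nn3)cc2)cc1`: 6%

Among the two measured compounds, compound 1 stands highest in a functional assay on MIA PaCa-2 cells (Homo sapiens) for inhibition, read by MTT assay, with a stated time of 48 h, tested at 10 uM (on this read-out higher numbers stand for more inhibition of growth at the one concentration tested and lower numbers for less inhibition of growth), and its nearest neighbour is compound 2. Going by the values given here, the single measured step, a number 13 percentage points lower from compound 1 to compound 2 (beyond the scatter), is beyond the scatter but modest, and it concerns the fluorophenyl on the saturated chain carbon bound to an aromatic nitrogen. Compound 3 `O=C(/C=C/c1ccc(OCc2cn(Cc3ccccc3F)nn2)cc1)c1ccc([N+](=O)[O-])cc1` differs from compound 1 elsewhere: nitro in place of methoxy on an aromatic carbon, so that the (4-methoxyphenyl)carbonyl becomes a (4-nitrophenyl)carbonyl while the fluorophenyl of compound 1 is kept. Among the compounds with values here, no measured step touches this carbonyl-side ring, so nothing among the numbers speaks directly for or against a change in this assay for this swap. With that gap, compound 3 is estimated at 22%, with a broad range from 5% to 50%. The expected step is therefore a number 3 percentage points higher from compound 1 to compound 3 (within the scatter), essentially no step beyond the scatter.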

Compound 3, percent growth inhibition at one concentration: 22%
Compound 3: middle estimate and measured number agree at the digits printed, and the stated range covers the measured number.
By their numbers in this assay, from the lowest: compound 2; then compounds 1 and 3 (each within the scatter of the next).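

In this assay the change from (4-methoxyphenyl)carbonyl to (4-nitrophenyl)carbonyl gives a number 3 percentage points higher from compound 1 to compound 3 (within the scatter) with the 2-fluorophenyl kept, so this first measured change on that ring leaves the number within the scatter. The earlier step concerned only the fluorophenyl and gave a number 13 percentage points lower from compound 1 to compound 2 (beyond the scatter); among these three compounds, only that fluorine change moves the number beyond the scatter. Nothing at hand explains why the swap of methoxy for nitro leaves the read-out within the scatter.

From the compounds shown here alone, it remains open whether an amine, a carboxylic acid or a plain hydrogen on this aromatic carbon would also stay within the scatter of compound 1. Going by these compounds, it is equally open whether nitro in place of methoxy would give a similar result with the 4-fluorophenyl of compound 2.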